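The source may report more compounds than this note shows. Statements on the series, on what has been measured and on what is new or still open speak of the compounds shown alone.

Compound 2 `CCCCCCOc1ccc(-n2cnnc2CCCCCC)cc1` gives only a limit in a functional assay on the whole organism (strain C57B/6) with Mus musculus as the target, in the maximal electroshock model (on this read-out lower numbers stand for an effect already at smaller amounts and higher numbers for an effect only at larger amounts of compound), reported as > 40 mg/kg. Compound 1 `CCCCCCOc1ccc(-n2cnnc2CCCCC)cc1` gives 32.8 mg/kg in this assay, and compound 3 `CCCCCCOc1ccc(-n2cnnc2-c2ccc(F)cc2)cc1` gives 22 mg/kg. Compound 4 `CCCCCCOc1ccc(-n2cnnc2-c2ccc(C)cc2)cc1` differs from compound 2 in one place: 4-methylphenyl in place of hexyl on an aromatic carbon. The nearest measured step is the one with 4-fluorophenyl in place of hexyl, an at least 1.8-fold lower number from compound 2 to compound 3 (0.25 log units; that floor lies within the scatter), and the related step of a 1.5-fold lower number from compound 1 to compound 3 (0.17 log units; within the scatter) points the same way, each time toward a lower number. Since compound 2 sits at the limit (the limit of > 40 mg/kg in this assay, at which 1 of the 3 values shown sits), the true size of the first of these steps is open. Compound 4 is therefore expected to reach a measurable dose, estimated at 25 mg/kg (range 14 mg/kg to 40 mg/kg), a step of an at least 1.6-fold lower number from compound 2 to compound 4 (0.20 log units; that floor lies within the scatter).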

Compound 4, dose for half-maximal effect: 11.4 mg/kg
The estimate for compound 4 lay 2.2-fold (0.34 log units) above the measured number; measured number outside the range, below it.
By their numbers in this assay, from the lowest: compounds 4, 3 and 1 (each within the scatter of the next, the first and the last beyond it). At a limit, above all of these: compound 2.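

Within the data shown here, at this aromatic carbon, 4-methylphenyl gives the first steps beyond the scatter in this assay: a 2.9-fold lower number from compound 1 to compound 4 (0.46 log units; beyond the scatter) against pentyl, and an at least 3.5-fold lower number from compound 2 to compound 4 (0.54 log units; beyond the scatter) against hexyl. Compound 2 is a limit, so the second step gives only a floor: the limit of > 40 mg/kg in this assay, at which 1 of the 4 values shown sits.
Methyl in place of fluoro does not separate the two phenyl compounds, a 1.9-fold lower number from compound 3 to compound 4 (0.29 log units; within the scatter), and 4-fluorophenyl does not clear the scatter against pentyl, so compound 3 goes against any general phenyl-over-chain reading.

Open, going by these compounds, is how an amine or a carboxylic acid in place of that methyl would read. Also open, on these data alone, is how the unsubstituted phenyl group would compare with 4-methylphenyl at this carbon.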